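The source may report more compounds than this note shows. Statements on the series, on what has been measured and on what is new or still open speak of the compounds shown alone.

Within the data shown here, compound 1 `COCc1ccccc1C1Cc2nccn2C1` is the stronger of the two compounds measured so far. In a functional assay on CHO cells for agonist activity at Alpha-1A adrenergic receptor (Homo sapiens), read by FLIPR and calcium flux (on this read-out lower numbers stand for an effect already at smaller amounts and higher numbers for an effect only at larger amounts of compound), compound 1 gives 82 nM, whereas compound 2 `COc1ccc(C2Cc3nccn3C2)cc1` in this assay gives 939 nM, a gap well beyond the usual scatter, so compound 1 holds the lowest number among the measured pair. Compound 3 `Clc1ccccc1C1Cc2nccn2C1` has not yet been measured in this assay. It differs from compound 1 in one place only: chloro in place of methoxymethyl on an aromatic carbon. The shared core of compound 1 is kept unchanged. Among the measured compounds shown here, no two measured compounds differ in exactly this way, so there is no measured step to lean on; what the data do show is that the pattern of compound 1, with its group on the ring in the same place as the chloro of compound 3, goes with the lower number, while compound 2 carries its group elsewhere and gives the higher one. On that basis the step from compound 1 to compound 3 is expected to be small, a 1.5-fold lower number from compound 1 to compound 3 (0.17 log units; within the scatter), not clearly beyond the scatter in either direction. Compound 3 is therefore estimated at 55 nM, with a range from 12 nM to 250 nM.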

Compound 3, half-maximal effective concentration: 19 nM
For compound 3 the middle estimate is 2.9-fold (0.46 log units) above the measured one, within the range that was stated.
By their numbers in this assay, from the lowest: compound 3; then compound 1; then compound 2.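

In this assay, among these compounds, the exchange of methoxymethyl for chloro gives a 4.3-fold lower number from compound 1 to compound 3 (0.64 log units; beyond the scatter) and so provides the first measured step at this position, the aromatic carbon ortho to a group of 8 heavy atoms. The step is modest but beyond the usual scatter, and it shows that the low number of compound 1 does not depend on methoxymethyl with its 3 heavy atoms and 1 hydrogen-bond acceptor: in compound 3, chloro, with 1 heavy atom and no hydrogen-bond acceptor, goes with a lower number still. The data offer no measurement that bears on what lies behind this change.

The compounds shown leave open whether the gain is particular to chloro or would also appear with fluoro, bromo or methyl on this carbon, and whether an amine or a carboxylic acid there would keep the number low. They also leave open whether chloro on another carbon of the ring would give a similar step, as this single pair speaks only for the one position in this assay.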